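Ether Chain Swaps on a Brominated Core: From Methoxy to Propargyloxy

A few compounds are considered here, and "the series" means these few. Any claim that something is new, unique, unknown or untested is made for them only; others in the source may bear on it.

Compound 1 `OCCOc1c(Br)cc(Br)cc1Oc1ccc(Br)cc1Br` in a functional assay on HL-60 cells (Homo sapiens) for cytotoxicity, read by MTT assay, with a stated time of 24 h (on this read-out higher numbers stand for weaker inhibition and lower numbers for stronger inhibition), gives 28.2 ug/mL.
Compound 2 `Brc1ccc(Oc2cc(Br)cc(Br)c2OCc2ccccc2)c(Br)c1` gives 27.9 ug/mL.
Compound 3 `COc1c(Br)cc(Br)cc1Oc1ccc(Br)cc1Br` gives 28.2 ug/mL.

Compound 3 sits level with compound 1 at the digits shown, and the two together hold the highest of the three numbers; the nearest neighbour is compound 1, with no change at the digits shown, and the furthest is compound 2, at a 1.0-fold higher number from compound 2 to compound 3 (0.00 log units; within the scatter). The step to the unmeasured compound 4 `C#CCOc1c(Br)cc(Br)cc1Oc1ccc(Br)cc1Br` is ethynyl in place of hydrogen on a saturated chain carbon bound to an oxygen on an aromatic ring. For the measured compounds named here, two measured steps touch the same place: no change at the digits printed from compound 1 to compound 3 (within the scatter) and a 1.0-fold higher number from compound 2 to compound 3 (0.00 log units; within the scatter), both within the scatter. Across a hydroxymethyl group, a phenyl group and a bare hydrogen the numbers barely moved, so a small ethynyl group at the same carbon is expected to leave the read-out where it is. Compound 4 is therefore estimated at 28 ug/mL, between 14 ug/mL and 56 ug/mL, a step of a 1.0-fold lower number from compound 3 to compound 4 (0.00 log units; within the scatter) expected to stay within the scatter.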

Compound 4, half-maximal inhibitory concentration: 29.7 ug/mL
Beside the measured number, compound 4's estimate is 1.1-fold (0.03 log units) below it; the measured number falls inside the stated range.
By their numbers in this assay, from the lowest: compounds 2, 1, 3 and 4 (each within the scatter of the next).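

An ethynyl group now joins hydroxymethyl, phenyl and hydrogen at this saturated chain carbon bound to an oxygen on an aromatic ring, and in this assay the change from methoxy to propargyloxy gives a 1.1-fold higher number from compound 3 to compound 4 (0.02 log units; within the scatter), so a triple bond here does not separate compound 4 from the methoxy compound. Against the other two groups the picture is the same, with a 1.1-fold higher number from compound 2 to compound 4 (0.03 log units; within the scatter) and a 1.1-fold higher number from compound 1 to compound 4 (0.02 log units; within the scatter), which leaves all four compounds level within the scatter. No measurement shown bears on why the read-out stays flat at this place.

The compounds shown leave open whether an amine, a carboxylic acid or a longer chain at this carbon would move the number beyond the scatter. They also leave open whether this flatness would hold in any other assay.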